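From an Aryl Ether to an Ethyl Ether

A few compounds are considered here, and "the series" means these few. Any claim that something is new, unique, unknown or untested is made for them only; others in the source may bear on it.

Three measured compounds share one core and differ only in the group on an oxygen on an aromatic ring. In a functional assay on HeLa cells (Homo sapiens) for antiproliferative activity, read by cell counting, with a stated time of 3 days (on this read-out higher numbers stand for weaker inhibition and lower numbers for stronger inhibition), compound 1 `CC(Nc1ccccc1Oc1ccc(Cl)cc1)=C1C(=O)CC(c2ccccc2)CC1=O` gives 500 nM. Compound 2 `CC(Nc1ccccc1Oc1cccc(F)c1)=C1C(=O)CC(c2ccccc2)CC1=O` gives 550 nM in this assay, the highest of the three numbers, though its gap to compound 1 lies within the scatter: a 1.1-fold higher number from compound 1 to compound 2 (0.04 log units; within the scatter). Compound 3 `CC(Nc1ccccc1Oc1ccc(N)cc1)=C1C(=O)CC(c2ccccc2)CC1=O` gives 39 nM, and the steps to it are large: a 13-fold lower number from compound 1 to compound 3 (1.11 log units; beyond the scatter) and a 14-fold lower number from compound 2 to compound 3 (1.15 log units; beyond the scatter).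

Compound 4 `CCOc1ccccc1NC(C)=C1C(=O)CC(c2ccccc2)CC1=O` has not been measured. Its change from compound 2 is ethyl in place of 3-fluorophenyl on an oxygen on an aromatic ring. Going by the values given here, no measured step shows what removing the aromatic ring here does: the step from compound 1 to compound 2 swaps 4-chlorophenyl for 3-fluorophenyl and stays within the scatter, and the large steps to compound 3 involve amino in place of chloro, which compound 4 does not carry. The expectation therefore rests on weak ground; a somewhat higher number, meaning weaker inhibition, is expected for compound 4, the step being a 1.6-fold higher number from compound 2 to compound 4 (0.21 log units; within the scatter). Compound 4 is estimated at 900 nM, within a range of 200 nM to 4000 nM.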

Compound 4, half-maximal inhibitory concentration: 180 nM
Compound 4: middle estimate off by 5.0-fold (0.70 log units), on the high side, outside the stated range (below it).
By their numbers in this assay, from the lowest: compound 3; then compound 4; then compounds 1 and 2 (each within the scatter of the next).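

The aromatic ring on this oxygen is not required for activity in this assay: ethyl, with no ring at all, gives a lower number than either 3-fluorophenyl (a 3.1-fold lower number from compound 2 to compound 4 (0.49 log units; beyond the scatter)) or 4-chlorophenyl (a 2.8-fold lower number from compound 1 to compound 4 (0.44 log units; beyond the scatter)). Yet removing the ring does not always help. Compound 3 goes against this trend, with ethyl in place of its 4-aminophenyl giving a higher number (a 4.6-fold higher number from compound 3 to compound 4 (0.66 log units; beyond the scatter)). So what matters at this position is not simply whether a ring is present, but which ring, and nothing available here explains why.

Still open, from the compounds shown here alone, is how the number responds to chain length on this oxygen, from methyl to a longer chain such as butyl. It is also unknown whether an amine at the end of such a chain would bring the same advantage as the amino group on the ring of compound 3.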